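The compounds below may be only part of what the source reports. "The series", "measured", "known", "first", "only" and "open" are said of these compounds alone.

Measured so far in a functional assay with Mus musculus as the target; on this read-out lower numbers stand for an effect already at smaller amounts and higher numbers for an effect only at larger amounts of compound:
- compound 1 `Nc1nc(O)c2c(n1)n(C1OC(CO)[C@@H](O)[C@H]1O)c(=O)n2C/C=C/c1ccccc1`: 4 uM
- compound 2 `Cn1c(=O)n(C2OC(CI)[C@@H](O)[C@H]2O)c2nc(N)nc(O)c21`: 52 uM

In this assay, compound 1 has the lower of the two numbers, and its gap to compound 2 lies beyond the scatter. Compound 3 `CCCCCCn1c(=O)n(C2OC(CO)[C@@H](O)[C@H]2O)c2nc(N)nc(O)c21` is still to be measured. Its change from compound 1 is pentyl in place of 2-phenylethenyl on a saturated chain carbon bound to an aromatic nitrogen. Going by the values given here, no measured pair isolates this exchange, so the expectation rests on judgement alone. A moderate move to a higher number in this assay is expected, and a result within the scatter of compound 1 would not be surprising. The expected size of the move is a 2.0-fold higher number from compound 1 to compound 3 (0.30 log units; within the scatter). For compound 3 the estimated value is 8 uM, with an expected range of 2 uM to 30 uM.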

Compound 3, concentration for half-maximal effect: 600 uM
Compound 3: the middle estimate sits 75-fold (1.88 log units) below what was measured; measured number outside the range, above it.
By their numbers in this assay, from the lowest: compound 1; then compound 2; then compound 3.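

In this assay, the group on the saturated chain carbon bound to an aromatic nitrogen has a strong bearing on the read-out: pentyl in place of 2-phenylethenyl gives a 150-fold higher number from compound 1 to compound 3 (2.18 log units; beyond the scatter), a large step beyond the scatter. The exchange removes the six-membered aromatic ring and the double bond together and leaves 5 heavy atoms where 8 stood, while the counts of hydrogen-bond donors, hydrogen-bond acceptors and net charge stay the same. No measurement at hand gives a cause for this step.

The compounds shown do not separate the contributions of the aromatic ring, the double bond and the length of the group. As far as these compounds go, a 3-phenylpropyl group, which keeps the ring without the double bond, and a chain ending in an amine or a carboxylic acid remain open at this place.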